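The source may report more compounds than this note shows. Statements on the series, on what has been measured and on what is new or still open speak of the compounds shown alone.

In a functional assay on PC-3 cells (Homo sapiens) for inhibition, read by MTT assay, with a stated time of 24 h, tested at 10 ug/mL (a lower number here means less inhibition of growth, a higher number more inhibition of growth at the concentration tested), compound 1 (`O=C(CCCCC1CCSS1)Nc1ccc(Cl)cn1`) gives 17.1% as its result. Compound 2 (`O=C(CCCCC(S)CCS)Nc1ccccn1`) has no single number there, and its entry reads "not determined" (no result reported) in the same test. Going to compound 3 (`O=C(CCCCC(S)CCS)Nc1ccc(Cl)cn1`), the change is chloro in place of hydrogen on an aromatic carbon and it puts chloro in place of hydrogen on an aromatic carbon. Within the data shown here, no measured step shows what this swap does, so a step beyond the scatter in this assay is not expected in either direction, and the estimate leans on compound 1 at 17.1% alone. Compound 3 is expected at 20% with an estimated range from 5% to 45% in this test.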

Compound 3, percent growth inhibition at one concentration: 10.8%
Compound 3: the middle estimate sits 9.2 percentage points above what was measured; the measured number falls inside the stated range.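

In this assay, a group of 3 carbon and 2 sulfur atoms with no ring, in place of the five-membered non-aromatic ring with the same atoms, gives a number 6.3 percentage points lower from compound 1 to compound 3 (within the scatter), so this test does not tell the ring and open forms apart at this saturated chain carbon. The step from hydrogen to chloro on the aromatic ring cannot be read, since compound 2 has no number. Nothing further on hand explains this result. From the compounds shown here alone, what a longer chain would do here remains open, as does an amine or a carboxylic acid in place of the chloro.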